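The source may hold more compounds than are shown below. What is called first, only, known or untested is meant among the compounds shown, and "the series" means these compounds.

In a functional assay on HCT-15 cells (Homo sapiens) for cytotoxicity, read by ELISA, with a stated time of 2 days (a lower number here means a stronger inhibitor, a higher number a weaker inhibitor), compound 1 (`Oc1ccc(-c2cc(-c3ccccc3)cc(-c3cccs3)n2)cc1`) gives 12500 nM and compound 2 (`Oc1cccc(-c2cc(-c3ccccc3)nc(-c3cccs3)c2)c1`) gives 14100 nM as its reading, so compound 2 stands level with compound 1 within the usual scatter of such measurements. Among the compounds with values here, no measured pair in this small set differs in a single place, so the data offer no step to lean on. Compound 3 (`Oc1cccc(-c2cc(-c3ccccc3)nc(-c3ccco3)c2)c1`) keeps the 3-hydroxyphenyl group and the phenyl group of compound 2 and alters one substituent, on an aromatic carbon next to the ring nitrogen: furan-2-yl in place of thiophen-2-yl (furan-2-yl in place of thiophen-2-yl on an aromatic carbon). With only compound 2 at 14100 nM as a guide and no measured swap of this kind to compare, no step beyond the scatter is expected in this assay in either direction. The expected change is a 1.1-fold lower number from compound 2 to compound 3 (0.04 log units; within the scatter) and would stay inside the scatter. For compound 3 the estimated value is 13000 nM with an expected range of 5500 nM to 30000 nM as the likely span.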

Compound 3, half-maximal inhibitory concentration: 13900 nM
The estimate for compound 3 lay 1.1-fold (0.03 log units) below the measured number; measured number inside the range.
By their numbers in this assay, from the lowest: compounds 1, 3 and 2 (each within the scatter of the next).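

In this assay, within the data shown here, the exchange of thiophen-2-yl for furan-2-yl, on an aromatic carbon next to the ring nitrogen, gives a 1.0-fold lower number from compound 2 to compound 3 (0.01 log units; within the scatter) and so provides the first comparison in this set that differs in a single place. With the 3-hydroxyphenyl group and the phenyl group held fixed, replacing the sulfur of this five-membered aromatic ring with oxygen leaves the reading within the scatter, so the two groups, which have the same counts of heavy atoms, hydrogen-bond donors and hydrogen-bond acceptors, cannot be told apart at this position. No measurement at hand explains this result, which stands as an observation only.

As far as these compounds go, both groups compared here are five-membered aromatic rings with one hetero atom, so it remains open whether this position would respond to a group of another kind, such as an amine, a carboxylic acid or a longer alkyl chain. From the compounds shown here alone, it is also open whether furan-2-yl and thiophen-2-yl would read alike on the core of compound 1, and this single step cannot settle that.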